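The source may hold more compounds than are shown below. What is called first, only, known or untested is meant among the compounds shown, and "the series" means these compounds.

Measured compounds:
compound 1, `Cc1nc(S(C)(=O)=O)ccc1Oc1ncnc(OC2CCN(C(=O)O[C@@H](C)CF)CC2)c1F`, 186 nM
compound 2, `Cc1nc(S(C)(=O)=O)ccc1Oc1ncnc(OC2CCN(C(=O)C3(C)CC3)CC2)c1F`, 761 nM

In a functional assay on isolated protein for inhibition of Glucose-dependent insulinotropic receptor (Homo sapiens), read by HTRF and cAMP accumulation (a higher number here means that more compound is needed for the effect, a lower number that less compound is needed), compound 1 holds the lowest of the two numbers; its nearest neighbour is compound 2, and the step of a 4.1-fold higher number from compound 1 to compound 2 (0.61 log units; beyond the scatter) lies beyond the scatter. Compound 3, `Cc1nc(S(C)(=O)=O)ccc1Oc1ncnc(OC2CCN(C(=O)c3noc(C(C)(C)F)n3)CC2)c1F`, has not been measured in this assay. It differs from compound 1 in one place: a group of 9 heavy atoms (5 carbon, 2 nitrogen, 1 oxygen, 1 fluorine; one five-membered aromatic ring with 3 hetero atoms) in place of a group of 5 heavy atoms (3 carbon, 1 oxygen, 1 fluorine; no ring), on a carbonyl carbon. Going by the values given here, the only measured step that bears on this is the one from compound 1 to compound 2, where the same group of 5 heavy atoms was replaced on the same carbonyl carbon and the number rose by a 4.1-fold higher number from compound 1 to compound 2 (0.61 log units; beyond the scatter). On that basis a rise of similar or somewhat smaller size is expected for compound 3, giving an estimated step of a 2.3-fold higher number from compound 1 to compound 3 (0.35 log units; beyond the scatter). Compound 3 is therefore estimated at 420 nM, with a likely range from 150 nM to 1200 nM.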

Compound 3, half-maximal effective concentration: 14 nM
Compound 3: middle estimate off by 30-fold (1.48 log units), on the high side, and the stated range ends above it.
By their numbers in this assay, from the lowest: compound 3; then compound 1; then compound 2.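

In this assay, going by these compounds alone, the carbonyl carbon whose other neighbours are an amide-type nitrogen in a ring proves able to move the number strongly downward, with a 13-fold lower number from compound 1 to compound 3 (1.12 log units; beyond the scatter) as the replacement group changes, whereas the only earlier step there went upward. Carrying a ring does not by itself settle the direction, as the five-membered aromatic ring with 3 hetero atoms gives a 54-fold lower number from compound 2 to compound 3 (1.74 log units; beyond the scatter) against the group with a three-membered non-aromatic ring of carbon only. Nothing measured here accounts for this difference.

The compounds shown do not separate the contribution of the aromatic ring from that of the fluorine-bearing group it carries. Going by these compounds, how the same ring with a plain methyl group, or a phenyl ring on the same carbonyl carbon, would read remains open.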